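The source may report more compounds than this note shows. Statements on the series, on what has been measured and on what is new or still open speak of the compounds shown alone.

Measured so far in a functional assay on HCC 2998 cells (Homo sapiens) for cytotoxicity, read by sulforhodamine B assay, with a stated time of 48 h; on this read-out lower numbers stand for higher toxicity in this test and higher numbers for lower toxicity in this test:

- compound 1, `ClCc1ccc(Cn2cnc3c(Cl)ncnc32)cc1`: 5120 nM
- compound 2, `ClCc1ccc(Cn2cnc3nc(Cl)nc(Cl)c32)cc1`: 7070 nM

Compound 1 stands at the lower of the two numbers, with compound 2 the nearest at a slightly higher number; the two values sit within the scatter of each other, so nothing separates them on this read-out. Within the data shown here, no step between measured compounds is recorded, and no structural difference between compound 1 and compound 2 is counted here, so their pair shows only two close values.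

Compound 3, `ClCc1ccc(Cn2cnc3c(Cl)nc(Cl)nc32)cc1`, differs from compound 1 by chloro in place of hydrogen on an aromatic carbon, in words: chloro in place of hydrogen on an aromatic carbon. Among the measured compounds shown here, with no measured step to lean on, the step from compound 1 to compound 3 is expected to be small, in either direction, and not beyond the scatter; the closeness of compound 1 at 5120 nM and compound 2 at 7070 nM gives no hint of a larger move. The expected step is a 1.2-fold higher number from compound 1 to compound 3 (0.07 log units; within the scatter). Compound 3 is estimated at 6000 nM in this assay, with a range from 2500 nM to 15000 nM.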

Compound 3, concentration lethal to 50% of the cells: 56200 nM
Beside the measured number, compound 3's estimate is 9.4-fold (0.97 log units) below it; the measured number lies above the stated range.
By their numbers in this assay, from the lowest: compounds 1 and 2 (each within the scatter of the next); then compound 3.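

In this assay, the aromatic carbon between two ring nitrogen atoms proves sensitive to substitution: chloro in place of hydrogen there gives an 11-fold higher number from compound 1 to compound 3 (1.04 log units; beyond the scatter), a large move towards lower toxicity in this test from the entry of a single heavy atom. Among these compounds, until this result, the series offered only two values within the scatter of each other and no step, so this is the first structural change with a readable consequence on this read-out. Nothing at hand accounts for the size of this step.

As far as these compounds go, the finding rests on one group at one position, so it remains open whether fluoro, bromo, an amine or a methoxy group on the same carbon would move the number as chloro does, or leave it close to the hydrogen of compound 1. Also open is whether the step would hold with a hydroxymethyl group in place of the chloromethyl group on the benzene-side part of the molecule, since every compound shown carries the chloromethyl group.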